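A few compounds are considered here, and "the series" means these few. Any claim that something is new, unique, unknown or untested is made for them only; others in the source may bear on it.

Of the compounds shown here, two have so far been measured in a functional assay on MCF7 cells (Homo sapiens) for antiproliferative activity, read by CCK-8 assay, with a stated time of 72 h (a higher number here means a weaker inhibitor, a lower number a stronger inhibitor), and both share one core. Compound 1 `COc1ccc(C(=O)Nc2cccc(-c3oc4cc(-c5ccc(F)cc5)ccc4c(=O)c3O)c2)cc1` gives 6250 nM, while compound 2 `O=C(Nc1cccc(-c2oc3cc(-c4ccc(F)cc4)ccc3c(=O)c2O)c1)c1ccc(C(F)(F)F)cc1` gives 32600 nM, the higher of the two numbers. Among the compounds with values here, the single step between them, a 5.2-fold higher number from compound 1 to compound 2 (0.72 log units; beyond the scatter), came from trifluoromethyl in place of methoxy on an aromatic carbon.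

Compound 3 `Cc1cccc(C(=O)Nc2cccc(-c3oc4cc(-c5ccc(F)cc5)ccc4c(=O)c3O)c2)c1` awaits measurement. It differs from compound 2 by 3-methylphenyl in place of 4-(trifluoromethyl)phenyl on a carbonyl carbon. Within the data shown here, only one measured step bears on this change, and only in part, since a methyl group is neither a methoxy nor a trifluoromethyl. Because the change a 5.2-fold higher number from compound 1 to compound 2 (0.72 log units; beyond the scatter) raised the number on introducing the trifluoromethyl, removing that group is expected to bring the number back down, by a 3.0-fold lower number from compound 2 to compound 3 (0.47 log units; beyond the scatter), though not all the way to the level of compound 1. Compound 3 is therefore estimated at 11000 nM, within a range of 3500 nM to 35000 nM.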

Compound 3, half-maximal inhibitory concentration: 7850 nM
Compound 3: the middle estimate sits 1.4-fold (0.15 log units) above what was measured; measured number inside the range.
By their numbers in this assay, from the lowest: compounds 1 and 3 (each within the scatter of the next); then compound 2.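

On the carbonyl carbon, replacing 4-(trifluoromethyl)phenyl with 3-methylphenyl gives a 4.2-fold lower number from compound 2 to compound 3 (0.62 log units; beyond the scatter) in this assay, so a second, different replacement also separates compound 2 from the other compounds. The comparison of the two lower-number compounds gives a 1.3-fold higher number from compound 1 to compound 3 (0.10 log units; within the scatter), placing 3-methylphenyl and 4-methoxyphenyl level in this assay, and among these three compounds only 4-(trifluoromethyl)phenyl stands apart. Since the substituent and its numbered place on the phenyl both change in this step, the two contributions cannot be separated, and no available evidence accounts for the differences.

As far as these compounds go, it remains open whether a plain phenyl on the same carbonyl carbon would stay level with compound 1 and compound 3. Also unresolved is how a phenyl carrying an amine or a carboxylic acid would fare.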